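Benzamide series, histone deacetylase 8: benzyloxycarbonyl step

This account rests on a few compounds, and the source may have more. Where it says the series, first, only, none or still open, it means among the compounds named here.

The shared core appears in compound 1 `Nc1cc2ccccc2cc1NC(=O)c1ccc(CNc2nccc(-c3cccnc3)n2)cc1`, compound 2 `Nc1ccccc1NC(=O)c1ccc(CSC2=N[C@@H](Cc3ccccc3)CS2)cc1` and compound 3 `Nc1cc(O)ccc1NC(=O)c1ccc(CNc2nccc(-c3cccnc3)n2)cc1`. In an assay for inhibition of histone deacetylase 8 (Homo sapiens), read by fluorescence, with stated times of 15 min and 60 min (a higher number here means a weaker inhibitor, a lower number a stronger inhibitor), compound 1 reaches only the limit of the assay, > 20000 nM. Compound 2 likewise gives only a limit in this assay, > 20000 nM. Compound 3 too returns only the limit > 20000 nM in this assay. For the measured compounds named here, the single counted step, a step that the two limits leave unreadable from compound 1 to compound 3, cannot be read, as the limit of > 20000 nM in this assay, at which 3 of the 3 values shown sit, shows.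

Compound 4 `Nc1cc(C(=O)OCc2ccccc2)ccc1NC(=O)c1ccc(CNc2nccc(-c3cccnc3)n2)cc1` differs from compound 3 by benzyloxycarbonyl in place of hydroxy on an aromatic carbon. Going by the values given here, no measured step bears on this change, since every value shown sits at the limit of > 20000 nM in this assay, at which 3 of the 3 values shown sit. Compound 4 is therefore expected to remain near the limit in this assay, with an estimated value of 20000 nM and a range from 5000 nM to 60000 nM. The expected step of a number no higher from compound 3 to compound 4 (the limit leaves the size open) is estimated to lie within the scatter.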

Compound 4, half-maximal inhibitory concentration: > 20000 nM
Compound 4: a limit, no number; the forecaster's own chance of this, stated with the estimate: 80%; the middle value sits exactly at the limit.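

No step can be read from compound 3 to compound 4, because both give a limit and not a number: the limit of > 20000 nM in this assay, at which 4 of the 4 values shown sit. The compounds shown leave open which change to the shared core, if any, would give a measurable value in this assay.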